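This account rests on a few compounds, and the source may have more. Where it says the series, first, only, none or still open, it means among the compounds named here.

Two compounds of the series carry a reading in a functional assay on C6 cells (Rattus norvegicus) for cytotoxicity, read by MTT assay, with a stated time of 24 h, tested at 100 ug/mL (a lower number here means a stronger effect, a higher number a weaker effect of the compound at the concentration tested), so far. Compound 1 `O=C(CSc1ncccn1)N/N=c1/scc(-c2ccc(Br)cc2)n1-c1ccccc1` gives 67.6% in this assay. Compound 2 `COc1ccc(-c2cs/c(=N/NC(=O)CSc3ncccn3)n2-c2ccccc2)cc1` gives 51.5% in this assay. Within the data shown here, the single measured step is a number 16.1 percentage points lower from compound 1 to compound 2 (beyond the scatter), so compound 2 stands at the lowest of the two numbers, with compound 1 as its only neighbour, higher by a margin beyond the scatter.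

The next compound, compound 3 `O=C(CSc1ncccn1)N/N=c1/scc(-c2ccc(F)cc2)n1-c1ccccc1`, differs from compound 2 by fluoro in place of methoxy on an aromatic carbon. Among the measured compounds shown here, the only step that bears on this change is the one from compound 1 to compound 2, where a halogen gave way to methoxy and the reading fell by a modest amount; here methoxy gives way to a halogen again, though a smaller one than bromo. On that basis the reading is expected to move back upward in this assay, by roughly the size of the measured step or somewhat less, with the direction more certain than the size. The estimate for compound 3 in this assay is 62%, with a range from 48% to 76%, which would mean a step of a number 10.5 percentage points higher from compound 2 to compound 3 (beyond the scatter).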

Compound 3, a percentage reported as activity, at one concentration (the size of the read-out at that concentration, not a potency): 53.4%
Beside the measured number, compound 3's estimate is 8.6 percentage points above it; low and high end bracket the measured number.
By their numbers in this assay, from the lowest: compounds 2 and 3 (each within the scatter of the next); then compound 1.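

In this assay, fluoro in place of methoxy on the aromatic carbon para to a large group gives a number 1.9 percentage points higher from compound 2 to compound 3 (within the scatter), so this change separates compound 2 and compound 3 by no more than the usual spread of the measurement. At the same carbon, fluoro in place of bromo gives a number 14.2 percentage points lower from compound 1 to compound 3 (beyond the scatter), which shows that the earlier difference between bromo and methoxy is not specific to methoxy, since a second group now also gives a reading clearly apart from that of bromo. Sharing a halogen therefore does not mean sharing a reading at this position, as compound 3 lies with compound 2 and apart from compound 1, and no supporting measurement is available to explain why bromo stands apart from the other two groups.

Among these compounds, with only three groups at this carbon, it remains open whether bromo is an isolated case or part of a wider trend that would also take in chloro, an amine, a carboxylic acid or a longer chain such as ethoxy. As far as these compounds go, the rest of the structure is identical in all three compounds, so it is also open whether the same differences would hold with a change elsewhere on the shared core.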